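A few compounds are considered here, and "the series" means these few. Any claim that something is new, unique, unknown or untested is made for them only; others in the source may bear on it.

Working notes on the series. Compound 1 `Cc1cc(Cl)ccc1-c1cccc(COc2ccc([C@H](CC(=O)O)c3ncnn3C)cc2)c1` gives 11 nM in a functional assay on A9 cells for agonist activity at Free fatty acid receptor 1 (Homo sapiens), read by inositol phosphate accumulation; on this read-out higher numbers stand for an effect only at larger amounts of compound and lower numbers for an effect already at smaller amounts. Compound 2 `Cc1cc(Cl)ccc1-c1cccc(COc2ccc([C@H](CC(=O)O)c3nnnn3C)cc2)c1` gives 1.3 nM in this assay; the step is an 8.5-fold lower number from compound 1 to compound 2 (0.93 log units; beyond the scatter). Compound 3 `Cc1nc(-c2ccc(C(F)(F)F)cc2)sc1COc1ccc([C@H](CC(=O)O)c2nccn2C)cc1`, built on another core, gives 16 nM in this assay. Compound 3 holds the highest of the three numbers shown; its gap to compound 1 is within the scatter, so no order between the two can be read, while its gap to compound 2 is beyond the scatter, and compound 2 stands clearly lower than both.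

Compound 4 `Cc1nc(-c2ccc(C(F)(F)F)cc2)sc1COc1ccc([C@H](CC(=O)O)c2nnnn2C)cc1` is not yet measured. It differs from compound 3 in one place: 1-methyl-1H-tetrazol-5-yl in place of 1-methyl-1H-imidazol-2-yl on a saturated chain carbon bound to an aromatic carbon and a saturated chain carbon. Within the data shown here, no measured pair shows a 1-methyl-1H-imidazol-2-yl exchanged for a 1-methyl-1H-tetrazol-5-yl. Among the measured compounds shown here, the one step that bears on it is an 8.5-fold lower number from compound 1 to compound 2 (0.93 log units; beyond the scatter), where a 1-methyl-1H-tetrazol-5-yl also entered on a saturated chain carbon bound to an aromatic carbon and a saturated chain carbon, though in exchange for a 1-methyl-1H-1,2,4-triazol-5-yl and on a different core. On that basis a lower number in this assay is expected for compound 4, with a step somewhat smaller than that one to allow for the different leaving ring and core. The estimate for compound 4 is 4 nM, with a range from 1.5 nM to 12 nM, which means an expected step of a 4.0-fold lower number from compound 3 to compound 4 (0.60 log units; beyond the scatter).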

Compound 4, half-maximal effective concentration: 3.8 nM
Compound 4: the middle estimate sits 1.1-fold (0.02 log units) above what was measured; measured number inside the range.
By their numbers in this assay, from the lowest: compound 2; then compound 4; then compounds 1 and 3 (each within the scatter of the next).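

In this assay the 1-methyl-1H-tetrazol-5-yl now lowers the number on a second core and against a second leaving ring (a 4.2-fold lower number from compound 3 to compound 4 (0.62 log units; beyond the scatter)), replacing 1-methyl-1H-imidazol-2-yl. The earlier step (an 8.5-fold lower number from compound 1 to compound 2 (0.93 log units; beyond the scatter)) had shown this only against 1-methyl-1H-1,2,4-triazol-5-yl on the core of compound 1, so the direction of the change on a saturated chain carbon bound to an aromatic carbon and a saturated chain carbon now holds in two pairs, and neither goes against it. No measurement shown bears on what lies behind either step.

The 1-methyl-1H-imidazol-2-yl and the 1-methyl-1H-1,2,4-triazol-5-yl each appear on one core only, so the three rings cannot be placed in a single order on a shared core. Also open, on these data alone, is what happens at this carbon with an ethyl in place of the methyl on the tetrazole ring, or with a plain phenyl in place of the five-membered ring.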